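Removing a Protecting Group: Effect on Cell Toxicity

A few compounds are considered here, and "the series" means these few. Any claim that something is new, unique, unknown or untested is made for them only; others in the source may bear on it.

Compound 1 `CC(C)(C)OC(=O)NCCCCN(CCCN(Cc1ccccc1)Cc1ccccc1)CCCN(Cc1ccccc1)Cc1ccccc1` and compound 2 `NCCCCN(CCCN(Cc1ccccc1)Cc1ccccc1)CCCN(Cc1ccccc1)Cc1ccccc1` share one core and differ in a single place. In an ADME assay on RAW264.7 cells (Mus musculus) for cytotoxicity, read by resazurin assay, with a stated time of 48 h (on this read-out higher numbers stand for lower toxicity in this test and lower numbers for higher toxicity in this test), compound 1 gives 12500 nM, while compound 2 gives 1200 nM. The change is hydrogen in place of tert-butoxycarbonyl on an amine nitrogen, and it produced a 10-fold lower number from compound 1 to compound 2 (1.02 log units; beyond the scatter), so the compound without the group was markedly more toxic to these cells.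

Compound 3 `CC(C)(C)OC(=O)NC1CCC(NCCCN(Cc2ccccc2)Cc2ccccc2)CC1` is built on a different core; the difference between the two cores is not broken down here. In this assay compound 3 gives 5100 nM. Compound 4 `NC1CCC(NCCCN(Cc2ccccc2)Cc2ccccc2)CC1` has not yet been measured. It differs from compound 3 by hydrogen in place of tert-butoxycarbonyl on an amine nitrogen. This is the same kind of change as that from compound 1 to compound 2, but not the same: in the earlier pair the amine nitrogen's other neighbour is a saturated chain carbon, whereas here it is a saturated ring carbon.

Because of a 10-fold lower number from compound 1 to compound 2 (1.02 log units; beyond the scatter) a step in the same direction, a 7.3-fold lower number from compound 3 to compound 4 (0.86 log units; beyond the scatter), is expected for compound 4. Since the surrounding carbon is not the same, the expected step is set somewhat smaller than the earlier one. Compound 4 is therefore estimated at 700 nM, with a likely range from 250 nM to 2000 nM.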

Compound 4, half-maximal cytotoxic concentration: 7600 nM
For compound 4 the middle estimate is 11-fold (1.04 log units) below the measured one; the whole stated range lies below it.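

In this assay, the same replacement of tert-butoxycarbonyl by hydrogen gave a 1.5-fold higher number from compound 3 to compound 4 (0.17 log units; within the scatter), so compound 3 and compound 4 cannot be told apart on this read-out. The sharp drop seen on the core of compound 1 therefore did not carry over to the core of compound 3: the same change on two cores in this assay, a 10-fold lower number (1.02 log units; beyond the scatter) from compound 1 to compound 2 and a 1.5-fold higher number (0.17 log units; within the scatter) from compound 3 to compound 4, 16-fold (1.19 log units) apart, beyond the scatter of two such steps. This shows that the result of this change on one core cannot simply be assumed on the other, but it does not show why the two differ, since the saturated chain carbon and saturated ring carbon on the amine nitrogen are only one part of what separates the cores.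

Two pairs also leave open how the same change would behave on any further core in this series. Nor do they show whether an acetyl group on that amine nitrogen, or a longer chain in place of the ring, would give numbers closer to the first pair or to the second.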